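Furan isomer steps on the shared core: next step

The source may report more compounds than this note shows. Statements on the series, on what has been measured and on what is new or still open speak of the compounds shown alone.

Compound 3 `c1ccc(-c2ccoc2)c(OCC2=NCCN2)c1` gives 0.501 nM in a functional assay for activation of Alpha-1A adrenergic receptor (Homo sapiens), read by calcium flux (on this read-out lower numbers stand for an effect already at smaller amounts and higher numbers for an effect only at larger amounts of compound), the lowest of the two numbers recorded. Its nearest neighbour compound 2 `c1coc(-c2ccccc2OCC2=NCCN2)c1` gives 1.26 nM, and the step of a 2.5-fold lower number from compound 2 to compound 3 (0.40 log units; beyond the scatter) is modest but beyond the scatter. Compound 1 `c1ccc(-c2ccncc2)c(OCC2=NCCN2)c1` reports only a limit of < 100000 nM. The steps a step that the limit leaves unreadable from compound 1 to compound 2 and a step that the limit leaves unreadable from compound 1 to compound 3 cannot be sized because of the limit of < 100000 nM in this assay, at which 1 of the 3 values shown sits.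

Compound 4 `Cc1ccoc1-c1ccccc1OCC1=NCCN1` differs from compound 3 by 3-methylfuran-2-yl in place of furan-3-yl on an aromatic carbon. Among the measured compounds shown here, the only measured step that bears on this change is a 2.5-fold lower number from compound 2 to compound 3 (0.40 log units; beyond the scatter), which runs the other way; the added methyl has no precedent. Compound 4 is therefore expected to give 1.5 nM (range 0.4 nM to 6 nM). The step of a 3.0-fold higher number from compound 3 to compound 4 (0.48 log units; beyond the scatter) is expected to be modest, roughly undoing the gain seen in a 2.5-fold lower number from compound 2 to compound 3 (0.40 log units; beyond the scatter).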

Compound 4, half-maximal effective concentration: 3.16 nM
For compound 4 the middle estimate is 2.1-fold (0.32 log units) below the measured one; measured number inside the range.
By their numbers in this assay, from the lowest: compound 3; then compound 2; then compound 4.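

Methyl in place of hydrogen on the furan ring gives the first readable substituent effect in the series: a 2.5-fold higher number from compound 2 to compound 4 (0.40 log units; beyond the scatter). Against the furan-3-yl of compound 3, the 3-methylfuran-2-yl group gives a 6.3-fold higher number from compound 3 to compound 4 (0.80 log units; beyond the scatter), so compound 4 has the highest of the three readable numbers. The step from compound 1 to compound 4 cannot be read, as compound 1 carries only a limit: the limit of < 100000 nM in this assay, at which 1 of the 4 values shown sits.

Going by these compounds, whether methyl on furan-3-yl carries a similar cost remains open. So does how an ethyl group or an amine on the furan ring would read out.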